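A Swapped Group on a Very Stable Compound

The source may hold more compounds than are shown below. What is called first, only, known or untested is meant among the compounds shown, and "the series" means these compounds.

So far two compounds have been measured. In an ADME assay on microsomes from liver (Homo sapiens) for metabolic stability, read by LC-MS, with a stated time of 30 min, tested at 1 uM (on this read-out lower numbers stand for a less stable compound and higher numbers for a more stable compound), compound 1 `O=C(NCc1ccc(S(=O)(=O)N2CCCCC2)cc1)c1cnc2nccn2c1` gives 64%. Compound 2 `O=C(NCc1ccc(S(=O)(=O)c2ccccc2)cc1)c1c[nH]c2ccncc12` reads > 99% in this assay, and this is a limit of the assay and not a number. It is the limit of > 99% in this assay, at which 1 of the 2 values shown sits, so compound 2 stands at the stable end of what has been measured.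

Compound 3 `O=C(NCc1ccc(S(=O)(=O)c2ccccc2)cc1)c1cnc2nccn2c1` has not yet been measured. It keeps compound 2 except for the group on the carbonyl carbon: a group of 9 heavy atoms (6 carbon, 3 nitrogen; one five-membered aromatic ring with 2 hetero atoms, one six-membered aromatic ring with 2 hetero atoms) in place of a group of 9 heavy atoms (7 carbon, 2 nitrogen; one five-membered aromatic ring with 1 hetero atom, one six-membered aromatic ring with 1 hetero atom), on a carbonyl carbon. The group that enters is also found in compound 1, which gives 64%, although that compound differs from compound 3 elsewhere. Within the data shown here, no pair of measured compounds differs in only one place, so this change has no measured precedent. Some loss of stability is nevertheless expected, probably beyond the usual scatter, though compound 3 should keep part of the stability of compound 2. The expected size of this fall is a number at least 17 percentage points lower from compound 2 to compound 3 (beyond the scatter). For compound 3 the estimated value in this assay is 82%, with an expected range from 60% to 98%.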

Compound 3, percent of the compound remaining: 60%
The estimate for compound 3 lay 22 percentage points above the measured number, within the range that was stated.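

The swap on the carbonyl carbon, between two groups of 9 heavy atoms, now has a measured size in this assay, and the step reads a number at least 39 percentage points lower from compound 2 to compound 3 (beyond the scatter). Compound 2 is held at a limit of the assay and not at a number, so this step gives only the least size of the fall: the limit of > 99% in this assay, at which 1 of the 3 values shown sits. The other step, phenyl in place of piperidin-1-yl on a sulfonyl sulfur with the group on the carbonyl carbon kept the same, reads a number 4 percentage points lower from compound 1 to compound 3 (within the scatter), so at this position the swap shows no difference that can be told from the scatter.

As far as these compounds go, each change rests on a single pair, so it remains open whether the swap on the carbonyl carbon would give a step of similar size with piperidin-1-yl on the sulfonyl sulfur, or whether the sulfonyl swap would stay within the scatter with the group of compound 2 on the carbonyl carbon. From the compounds shown here alone, how a morpholine or an open-chain amine on the sulfonyl sulfur, or a plain phenyl on the carbonyl carbon, would read in this assay also remains open.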